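The source may report more compounds than this note shows. Statements on the series, on what has been measured and on what is new or still open speak of the compounds shown alone.

Measured set, all in a functional assay on HepG2 cells (Homo sapiens) for inhibition, read by MTT assay, with a stated time of 72 h; on this read-out higher numbers stand for weaker inhibition and lower numbers for stronger inhibition:
Compound 1 `Cc1ccc(-n2cc(CNC(=O)c3cccc4c3cnn4C(C)C)nn2)cc1C` gives > 40000 nM, a limit of the assay.
Compound 2 `CC(C)n1ncc2c(C(=O)NCc3cn(-c4ccc(F)cc4)nn3)cccc21` gives > 40000 nM, likewise a limit.
Compound 3 `CC(C)n1ncc2c(C(=O)NCc3cn(-c4cccc(Br)c4)nn3)cccc21` gives > 40000 nM, again only a limit.

Compound 3 therefore stands at the common limit, (the limit of > 40000 nM in this assay, at which 3 of the 3 values shown sit), with no number to set it against the others. The change to compound 4 `Cc1ccc(-n2cc(CNC(=O)c3cccc4c3cnn4C(C)C)nn2)cc1` is 4-methylphenyl in place of 3-bromophenyl on an aromatic nitrogen. The steps at this position, a step that the two limits leave unreadable from compound 1 to compound 3, a step that the two limits leave unreadable from compound 2 to compound 3 and a step that the two limits leave unreadable from compound 1 to compound 2, are all unreadable in size because the limit of > 40000 nM in this assay, at which 3 of the 3 values shown sit, covers both ends of each. For the measured compounds named here, nothing among the measured aryl groups on this nitrogen has reached a readable value. The expected step is a step that the limit leaves unreadable from compound 3 to compound 4, no change beyond the scatter. Compound 4 is estimated at 60000 nM, range 25000 nM to 150000 nM, most likely reported again as a limit.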

Compound 4, half-maximal inhibitory concentration: > 40000 nM
Compound 4: only a limit was reported (the forecaster's own chance of this, stated with the estimate: 85%); the middle value is on the limit's open side.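

In this assay compound 4 gives > 40000 nM as a limit of the assay. Its steps from compound 1, compound 2 and compound 3 cannot be read in size: the limit of > 40000 nM in this assay, at which 4 of the 4 values shown sit.
Going by these compounds, whether any aryl group on this nitrogen gives a readable value remains open.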